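Thiophene for Phenyl on the Imine Carbon

This account rests on a few compounds, and the source may have more. Where it says the series, first, only, none or still open, it means among the compounds named here.

Compound 1, `NS(=O)(=O)c1ccc(Nc2ncc(/N=C/c3cccs3)c(NC3CCCC3)n2)cc1`: 23000 nM in a functional assay on MCF7 cells (Homo sapiens) for antiproliferative activity, read by MTT assay; on this read-out lower numbers stand for stronger inhibition and higher numbers for weaker inhibition.
Compound 2, `CCOC(=O)/C=N/c1cnc(Nc2ccc(S(N)(=O)=O)cc2)nc1NC(C)C`: 58800 nM.
Compound 3, `CC(C)Nc1nc(Nc2ccc(S(N)(=O)=O)cc2)ncc1/N=C/c1ccccc1`: > 100000 nM.

Compound 3 stands only at a limit in this assay, the value > 100000 nM being a limit and not a number, as at the limit of > 100000 nM in this assay, at which 1 of the 3 values shown sits. Compound 4, `CC(C)Nc1nc(Nc2ccc(S(N)(=O)=O)cc2)ncc1/N=C/c1cccs1`, differs from it by thiophen-2-yl in place of phenyl on a carbon with a double bond to nitrogen. Going by the values given here, no measured step swaps these two groups alone. The step of an at least 1.7-fold higher number from compound 2 to compound 3 (0.23 log units; that floor lies within the scatter) brought phenyl in, and compound 1, which carries the thiophen-2-yl with a different amine, gives 23000 nM. A lower number is therefore expected for compound 4, estimated at 45000 nM with a range from 15000 nM to 150000 nM. This expected step would be an at least 2.2-fold lower number from compound 3 to compound 4 (0.34 log units; beyond the scatter).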

Compound 4, half-maximal inhibitory concentration: 50200 nM
Beside the measured number, compound 4's estimate is 1.1-fold (0.05 log units) below it; measured number inside the range.
By their numbers in this assay, from the lowest: compound 1; then compounds 4 and 2 (each within the scatter of the next). At a limit, above all of these: compound 3.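

In this assay compound 3 is held at a limit and not a number, so the change from phenyl to thiophen-2-yl reads only as an at least 1.9-fold lower number from compound 3 to compound 4 (0.29 log units; that floor lies within the scatter): the limit of > 100000 nM in this assay, at which 1 of the 4 values shown sits.
Thiophen-2-yl and ethoxycarbonyl on this carbon are not told apart, with a 1.2-fold lower number from compound 2 to compound 4 (0.07 log units; within the scatter).
The amine matters more clearly, as isopropyl in place of cyclopentyl gives a 2.2-fold higher number from compound 1 to compound 4 (0.34 log units; beyond the scatter).
From the compounds shown here alone, whether cyclopentyl would bring the same shift alongside phenyl or ethoxycarbonyl stays open.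
So does what a carboxylic acid on this carbon, or a longer chain on the amine nitrogen, would give.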